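From Pyridin-2-yl to Benzoyl on a Sulfur Chain

The source may hold more compounds than are shown below. What is called first, only, known or untested is meant among the compounds shown, and "the series" means these compounds.

In an ADME assay on MT4 cells (Homo sapiens) for cytotoxicity, read by MTT assay (on this read-out higher numbers stand for lower toxicity in this test and lower numbers for higher toxicity in this test), compound 2 `Cc1c(Cc2c(F)cccc2F)nc(SCc2ccccn2)[nH]c1=O` gives > 70000 nM, which is a limit of the assay and not a number. Compound 1 `O=c1cc(Cc2c(F)cccc2F)nc(Sc2ccccc2)[nH]1` reads > 76000 nM, also a limit. Compound 3 `O=C(CSc1nc(Cc2c(F)cccc2Cl)cc(=O)[nH]1)c1ccc(F)cc1`, which has a carbonyl in its sulfur chain, reads > 61000 nM, again a limit. Compound 2 therefore stands with the other two compounds, and none of the three gives a measured number to rank it by.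

The next compound is compound 4 `Cc1c(Cc2c(F)cccc2F)nc(SCC(=O)c2ccccc2)[nH]c1=O`, which has benzoyl in place of pyridin-2-yl on a saturated chain carbon bound to a sulfur. Among the measured compounds shown here, no measured pair shows this change alone. With its limit of > 61000 nM, compound 3 offers the nearest guide, and no step beyond the scatter is expected in this assay, in either direction. The estimated at least 1.1-fold lower number from compound 2 to compound 4 (0.06 log units; that floor lies within the scatter) is expected to stay within the usual scatter. For compound 4 the estimated value is 60000 nM, with an expected range from 20000 nM to 100000 nM.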

Compound 4, half-maximal cytotoxic concentration: 65000 nM
Estimate against measurement, compound 4: 1.1-fold (0.03 log units) below; measured number inside the range.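

Among the compounds shown here, compound 4, with benzoyl on a saturated chain carbon bound to a sulfur, is the first compound here whose reading in this assay is a number and not a limit. Against the compound carrying pyridin-2-yl at this place, the change reads as an at least 1.0-fold lower number from compound 2 to compound 4 (0.03 log units; that floor lies within the scatter), so this exchange shows no step beyond the usual scatter. The reading of compound 2 remains a limit of the assay, so that step is only a floor: the limit of > 70000 nM in this assay, at which 1 of the 4 values shown sits.

The compounds shown leave open how far the true value of compound 2 lies from its limit, and so the real size of the step. They also leave open whether an amine or a carboxylic acid in place of benzoyl, or a longer chain on the sulfur, would stand apart from compound 4 in this assay.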